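The source may hold more compounds than are shown below. What is called first, only, known or untested is meant among the compounds shown, and "the series" means these compounds.

The shared core carries one side group that changes from compound to compound. Compound 1 `CCCCCCNc1[nH]ccc2ncnc1-2` bears a hexylamino group, and in a functional assay on EL4 cells (Mus musculus) for inhibition, tested at 100 uM (a higher number here means more inhibition at the concentration tested (going by the name of the read-out), a lower number less inhibition), compound 1 gives 100%. Compound 2 `[N-]=[N+]=Nc1[nH]ccc2ncnc1-2` carries an azido group instead. In this assay compound 2 only reaches the assay limit of < 5% (the limit of < 5% in this assay, at which 1 of the 2 values shown sits). Compound 3 `CCNc1[nH]ccc2ncnc1-2` is not yet measured; it differs from compound 2 by ethylamino in place of azido on an aromatic carbon. A large upward step from compound 2 to compound 3 is expected in this assay, since compound 1 with its hexylamino group gives 100%. Compound 3 is therefore estimated at 60%, between 15% and 100%, an expected rise of a number at least 55 percentage points higher from compound 2 to compound 3 (beyond the scatter).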

Compound 3, a percentage reported as inhibition, at one concentration (the size of the read-out at that concentration, not a potency): < 5%
Compound 3 gave a limit, no number; the forecaster's own chance of this, stated with the estimate: 15%; middle value at least 55 percentage points from the limit.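

In this assay, shortening the hexylamino chain to ethylamino gives a number at least 95 percentage points lower from compound 1 to compound 3 (beyond the scatter). At this position, then, an amino group on the aromatic carbon is not enough for inhibition, and the length of the chain attached to it matters. The step from azido to ethylamino cannot be read, because both compounds rest on a limit rather than a number: the limit of < 5% in this assay, at which 2 of the 3 values shown sit.

From the compounds shown here alone, whether a butylamino group would already bring inhibition back remains open. So does whether a longer chain, such as octylamino, would keep it.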